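The compounds below may be only part of what the source reports. "The series", "measured", "known", "first", "only" and "open" are said of these compounds alone.

Measured compounds in an ADME assay on HEp-2 cells (Homo sapiens) for cytotoxicity, read by MTT assay, with a stated time of 3 days; a higher number here means that more compound is tolerated, a lower number that less compound is tolerated:
Compound 1, `CC[C@H](CCn1cncn1)c1ccccc1`: 97.7 ug/mL
Compound 2, `CC[C@H](CCn1cncn1)c1ccc(Cl)cc1`: 50.6 ug/mL
Compound 3, `CC[C@H](CCn1cncn1)c1ccc(C)cc1`: 75.2 ug/mL

Compound 3 stands second highest of the three numbers in this assay, but all three lie within the usual scatter of one another: the step of a 1.3-fold lower number from compound 1 to compound 3 (0.11 log units; within the scatter) and the step of a 1.5-fold higher number from compound 2 to compound 3 (0.17 log units; within the scatter) are both small, as is the step of a 1.9-fold lower number from compound 1 to compound 2 (0.29 log units; within the scatter) between the other two. For the measured compounds named here, no compound here can be called better or worse tolerated than another on these numbers.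

Compound 4, `CC[C@H](CCn1cncn1)c1ccc(OC)cc1`, differs from compound 3 by a single change: methoxy in place of methyl on an aromatic carbon. The measured steps that bear on this change are the three just named, since each of them also swaps one small substituent on the same aromatic carbon, and none of them moved the number beyond the scatter. Going by the values given here, nothing among the measured compounds carries a methoxy, so there is no direct precedent for the entering group; what the data offer is that small changes at this position have so far left the read-out essentially unchanged.

Compound 4 is therefore expected to show a step of a 1.0-fold higher number from compound 3 to compound 4 (0.02 log units; within the scatter), that is, no change beyond the scatter. The estimate for compound 4 in this assay is 78 ug/mL, with a range from 42 ug/mL to 145 ug/mL.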

Compound 4, half-maximal cytotoxic concentration: 153 ug/mL
For compound 4 the middle estimate is 2.0-fold (0.29 log units) below the measured one, and the stated range ends below it.
By their numbers in this assay, from the lowest: compounds 2, 3, 1 and 4 (each within the scatter of the next, the first and the last beyond it).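

For the compounds shown here, at this position, on an aromatic carbon para to a large group, methoxy is the first substituent to move the number in this assay beyond the scatter, with a 2.0-fold higher number from compound 3 to compound 4 (0.31 log units; beyond the scatter) and a 3.0-fold higher number from compound 2 to compound 4 (0.48 log units; beyond the scatter), both modest, so the position is not as indifferent to small swaps as the earlier compounds suggested. The separation holds only against methyl and chloro, since a 1.6-fold higher number from compound 1 to compound 4 (0.19 log units; within the scatter) leaves methoxy not distinguishable from the plain hydrogen of compound 1, and the result is therefore a gap between substituted compounds rather than a clear gain over the unsubstituted one. Nothing available explains why methoxy parts from methyl and chloro here.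

The compounds shown leave open whether the oxygen of the methoxy or the group as a whole carries this step, which a hydroxy or an ethoxy on the same aromatic carbon would help to decide. They also leave open how an amine or a carboxylic acid at this place would read in this assay, and whether methoxy would give the same steps on another carbon of the ring.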